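Lengthening the sulfur chain: from compound 2 to compound 3

A few compounds are considered here, and "the series" means these few. Any claim that something is new, unique, unknown or untested is made for them only; others in the source may bear on it.

Measured so far:
compound 1, `CSc1nnc(Cc2ccc(Cl)cc2Oc2ccccc2Cl)[nH]1` — 132%
compound 2, `CSc1nnc(Cc2ccc(Cl)cc2Oc2ccccc2F)[nH]1` — 121%

In a functional assay on the whole organism (strain NMRI) with Mus musculus as the target, with a stated time of 60 min, at a dose of 10 mg/kg by the intraperitoneal route (a lower number here means a weaker effect, a higher number a stronger effect of the compound at the dose given), compound 1 gives 132%, and compound 2 gives 121%. Among the compounds with values here, the single measured step, a number 11 percentage points lower from compound 1 to compound 2 (beyond the scatter), goes with fluoro in place of chloro on an aromatic carbon. Compound 2 therefore stands lowest of the two numbers, and the gap to compound 1 is beyond the scatter.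

Compound 3, `CCCSc1nnc(Cc2ccc(Cl)cc2Oc2ccccc2F)[nH]1`, is not yet measured. It differs from compound 2 by ethyl in place of hydrogen on a saturated chain carbon bound to a sulfur, so the methylsulfanyl group becomes a propylsulfanyl group while the rest of the molecule is unchanged. Within the data shown here, the only measured step concerns the halogen on the aromatic ring and says nothing about the chain on the sulfur, so no measured step bears on this change. With nothing pointing either way, the expectation is no step beyond the scatter, that is no change at the digits printed from compound 2 to compound 3 (within the scatter). Compound 3 is thus estimated at 121%, with a range from 100% to 142%.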

Compound 3, a percentage reported as activity, at one dose (the size of the read-out at that dose, not a potency): 127%
Compound 3: the middle estimate sits 6 percentage points below what was measured; the range from low to high includes it.
By their numbers in this assay, from the lowest: compounds 2, 3 and 1 (each within the scatter of the next, the first and the last beyond it).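

The sulfur chain is the new position here, and in this assay the change from methylsulfanyl to propylsulfanyl gives a number 6 percentage points higher from compound 2 to compound 3 (within the scatter). The two compounds therefore cannot be told apart in this read-out, so the effect at this dose does not depend on the sulfur carrying methyl rather than propyl. No measurement at hand explains why the ethyl added to the chain makes no clear difference.

The compounds shown do not reveal how far this tolerance extends: a longer chain such as hexyl, a branched one such as isopropyl, or a chain ending in an amine or a carboxylic acid could behave differently. They also leave open whether propylsulfanyl would give the same result with chloro in place of fluoro on the aromatic ring, and because each number comes from a single dose, they cannot show whether the potency of the two compounds is also alike.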